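The compounds below may be only part of what the source reports. "The series", "measured", "known", "first", "only" and "open" are said of these compounds alone.

For the measured compounds named here, compound 2 `Cc1ccc(C)c(C(=O)Nc2cc(Cl)ccc2OCC(=O)Nc2ccc(S(N)(=O)=O)cc2C)c1` is one of two compounds measured in a functional assay on C8166 cells (Homo sapiens) for cytotoxicity, read by MTT assay (a higher number here means that more compound is tolerated, a lower number that less compound is tolerated), where compound 2 gives 79700 nM. Going by the values given here, compound 1 `Cc1cccc(C(=O)Nc2cc(Cl)ccc2OCC(=O)Nc2ccc(S(N)(=O)=O)cc2C)c1` gives 52900 nM in this assay, and the only measured step, a 1.5-fold higher number from compound 1 to compound 2 (0.18 log units; within the scatter), concerns a small change elsewhere on the shared core. Among the compounds with values here, compound 3 `Cc1cc(S(N)(=O)=O)ccc1NC(=O)COc1ccc(Cl)cc1NC(=O)c1cc(Cl)cc(C#N)c1` carries a different change, (3-chloro-5-cyanophenyl in place of 2,5-dimethylphenyl on a carbonyl carbon), on the other side of the molecule, and no measured step speaks to it. For compound 3 a step of a 1.1-fold lower number from compound 2 to compound 3 (0.06 log units; within the scatter) is expected, that is, nothing beyond the scatter. Compound 3 is therefore estimated at 70000 nM in this assay, with a range of 30000 nM to 160000 nM.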

Compound 3, half-maximal cytotoxic concentration: 131000 nM
Estimate against measurement, compound 3: 1.9-fold (0.27 log units) below; the measured number falls inside the stated range.
By their numbers in this assay, from the lowest: compounds 1, 2 and 3 (each within the scatter of the next, the first and the last beyond it).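

In this assay the carbonyl carbon's aryl group can change far more than a single methyl: 3-chloro-5-cyanophenyl in place of 2,5-dimethylphenyl gives a 1.6-fold higher number from compound 2 to compound 3 (0.22 log units; within the scatter) and so stays within the scatter. For the compounds shown here, in place of 3-methylphenyl, the same group gives a 2.5-fold higher number from compound 1 to compound 3 (0.39 log units; beyond the scatter) and this is the only step here beyond the scatter, though a modest one. Nothing available explains these numbers. As far as these compounds go, it remains open whether the chlorine or the nitrile alone would give the step from 3-methylphenyl. An amine or a carboxylic acid on this ring also remains untested in the compounds shown.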